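The compounds below may be only part of what the source reports. "The series", "measured", "known", "first", "only" and "open" are said of these compounds alone.

Working notes on the series

Two compounds of this series carry a number. Compound 1, `CCCS(=O)(=O)N1CCN(c2ccc(OCC3CCN(C(=O)NC(C)C)CC3)cn2)CC1`, gives in a functional assay on CHO-K1 cells for agonist activity at Glucose-dependent insulinotropic receptor (Homo sapiens), read by a luciferase reporter, with a stated time of 5 h (a higher number here means that more compound is needed for the effect, a lower number that less compound is needed), a half-maximal effective concentration of 1000 nM. Compound 2, `CCS(=O)(=O)N1CCN(c2ccc(OCCC3CCN(C(=O)OC(C)C)CC3)cn2)CC1`, gives in this assay a value of 1200 nM. Among the compounds with values here, of the two numbers, the one for compound 2 is the higher; compound 1 is its nearest neighbour, and the gap between them lies within the scatter, so no order can be read from the pair. Within the data shown here, the two compounds differ in more than one place, and no single-change step between measured compounds is available.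

Compound 3, `CCCS(=O)(=O)N1CCN(c2ccc(OCCC3CCN(C(=O)OC(C)C)CC3)cn2)CC1`, is not yet measured. Compared with compound 2 it shows (methyl in place of hydrogen on a saturated chain carbon, two bonds along the chain from a sulfonyl sulfur). Without any step of this kind among the measured compounds, the expectation rests on the closeness of compound 1 and compound 2 alone: no shift beyond the scatter is expected, and the estimated step is a 1.2-fold lower number from compound 2 to compound 3 (0.08 log units; within the scatter). For compound 3 in this assay the expected half-maximal effective concentration is 1000 nM, with a range from 400 nM to 2500 nM.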

Compound 3, half-maximal effective concentration: 700 nM
Estimate against measurement, compound 3: 1.4-fold (0.15 log units) above, within the range that was stated.
By their numbers in this assay, from the lowest: compounds 3, 1 and 2 (each within the scatter of the next).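

In this assay, within the data shown here, the change from ethylsulfonyl to propylsulfonyl gives a 1.7-fold lower number from compound 2 to compound 3 (0.23 log units; within the scatter) as the first single-change reading, so a methyl in place of hydrogen on a saturated chain carbon, two bonds along the chain from a sulfonyl sulfur, is tolerated here without a shift beyond the scatter. Compound 1 and compound 2 differ in more than one place, so that pair could say nothing about this position taken alone, whereas this step isolates it for the carbamate-bearing compounds. No measurement at hand accounts for the size of this step.

As far as these compounds go, whether a longer chain such as butyl, a branched isopropyl or a cyclopropyl ring on the sulfonyl sulfur would move the number beyond the scatter remains open, as does the effect of the shorter methylsulfonyl group. Also open, from the compounds shown here alone, is how an amine or a hydroxyl on this chain carbon would read in this assay, since one step with a methyl does not describe the wider tolerance of this position.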